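A few compounds are considered here, and "the series" means these few. Any claim that something is new, unique, unknown or untested is made for them only; others in the source may bear on it.

Compound 1 `COc1cc(-c2nnc3n2NC(c2ccco2)C(C(=O)c2cccs2)S3)cc(OC)c1OC` is one of three close relatives carrying the same core and a furan-2-yl group next to the ring nitrogen, differing only in the group on the carbonyl carbon. In a functional assay on MCF7 cells (Homo sapiens) for cytotoxicity, read by MTT assay, with a stated time of 48 h (a lower number here means a stronger inhibitor, a higher number a weaker inhibitor), compound 1 reaches only the limit of the assay, > 100000 nM, rather than a number. Compound 2 `COc1cc(-c2nnc3n2NC(c2ccco2)C(C(=O)C2CC2)S3)cc(OC)c1OC`, with cyclopropyl on that carbonyl carbon, likewise gives only the limit > 100000 nM in this assay. Among the compounds with values here, compound 3 `COc1cc(-c2nnc3n2NC(c2ccco2)C(C(=O)c2cccc(Br)c2)S3)cc(OC)c1OC`, with 3-bromophenyl there, is the only one to return a number, 91800 nM in this assay. The step that the two limits leave unreadable from compound 1 to compound 2 cannot be read, while an at least 1.0-fold lower number from compound 1 to compound 3 (0.03 log units; that floor lies within the scatter) and an at least 1.0-fold lower number from compound 2 to compound 3 (0.03 log units; that floor lies within the scatter) show only a floor that lies within the scatter, because the limit of > 100000 nM in this assay, at which 2 of the 3 values shown sit, caps what can be seen for two of the three compounds.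

Compound 4 `COc1cc(-c2nnc3n2NC(c2ccco2)C(C(=O)c2ccco2)S3)cc(OC)c1OC` takes the step (furan-2-yl in place of thiophen-2-yl on a carbonyl carbon). Within the data shown here, no measured step bears directly on this exchange, and the three that exist show no movement beyond the scatter, so no step beyond the scatter is expected in this assay. The estimated step is a number no higher from compound 1 to compound 4 (the limit leaves the size open). Compound 4 is therefore expected to give about 100000 nM in this assay, within a range from 50000 nM to 300000 nM, most likely again reported only as a limit.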

Compound 4, half-maximal inhibitory concentration: > 100000 nM
Compound 4: no number, only a limit (the forecaster's own chance of this, stated with the estimate: 70%); the middle value lies on the limit itself.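

In this assay compound 4 gives > 100000 nM, which is a limit of the assay and not a number. Within the data shown here, the steps from compound 1 and from compound 2 to compound 4 cannot be read, so the exchange of thiophen-2-yl for furan-2-yl on this carbonyl carbon has no measurable size, and the only readable step is an at least 1.0-fold higher number from compound 3 to compound 4 (0.03 log units; that floor lies within the scatter). Swapping one five-membered aromatic ring with 1 hetero atom for another thus adds a further group to those that leave the compounds at the edge of what the assay can show, and any real difference among them stays hidden: the limit of > 100000 nM in this assay, at which 3 of the 4 values shown sit.

The compounds shown leave open whether any group on this carbonyl carbon can bring the value clearly below the limit, for example an amine or a longer chain in place of the thiophen-2-yl. They also leave open how much the furan-2-yl group that all four compounds share contributes, and whether a carboxylic acid or an amine in its place would give a number that can be compared.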